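A few compounds are considered here, and "the series" means these few. Any claim that something is new, unique, unknown or untested is made for them only; others in the source may bear on it.

Measured compounds in an assay on LtK cells with ATP-sensitive inward rectifier potassium channel 11 (Homo sapiens) as the target; a lower number here means that less compound is needed, a higher number that more compound is needed for the effect:
- compound 1, `CC(=O)Nc1c(C(O)(C(F)(F)F)C(F)(F)F)ccc2ccccc12`, gives 18 nM
- compound 2, `CC(C)C(=O)Nc1c(C(O)(C(F)(F)F)C(F)(F)F)ccc2ccccc12`, gives 6630 nM
- compound 3, `O=C(CC1CCCC1)Nc1c(C(O)(C(F)(F)F)C(F)(F)F)ccc2ccccc12`, gives 81 nM

Compound 3 stands second of the three. Its nearest neighbour is compound 1, from which it differs by a 4.5-fold higher number from compound 1 to compound 3 (0.65 log units; beyond the scatter); its most distant is compound 2, from which it differs by an 82-fold lower number from compound 2 to compound 3 (1.91 log units; beyond the scatter). The branched group on the carbonyl carbon in compound 2 is the outlier, as a 370-fold higher number from compound 1 to compound 2 (2.57 log units; beyond the scatter) shows.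

Compound 4, `O=C(NCCCCCCCl)Nc1c(C(O)(C(F)(F)F)C(F)(F)F)ccc2ccccc12`, has not yet been measured. The change from compound 3 is (6-chlorohexyl)amino in place of cyclopentylmethyl on a carbonyl carbon, so the amide becomes a urea and a straight chain ending in chlorine replaces the ring. For the measured compounds named here, no measured pair carries exactly this change. Going by the values given here, two steps bear on it indirectly: the large loss from compound 1 to compound 2 with a branched group, and the smaller loss from compound 1 to compound 3 with an unbranched one. Compound 4 keeps an unbranched chain, so a shift of the modest kind, not the large one, is expected in this assay, most likely toward a higher number. The estimated step is a 2.0-fold higher number from compound 3 to compound 4 (0.30 log units; within the scatter), and compound 4 is expected to give 160 nM, in the range 30 nM to 900 nM.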

Compound 4, half-maximal effective concentration: 4840 nM
The estimate for compound 4 lay 30-fold (1.48 log units) below the measured number, and the stated range ends below it.
By their numbers in this assay, from the lowest: compound 1; then compound 3; then compounds 4 and 2 (each within the scatter of the next).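

In this assay, putting (6-chlorohexyl)amino in place of cyclopentylmethyl on this carbonyl carbon gives a 60-fold higher number from compound 3 to compound 4 (1.78 log units; beyond the scatter), and the comparison with the smallest group shown gives a 270-fold higher number from compound 1 to compound 4 (2.43 log units; beyond the scatter), so an unbranched group at this position does not by itself keep the number low. The straight chain also ends up level with the branched isopropyl group, at a 1.4-fold lower number from compound 2 to compound 4 (0.14 log units; within the scatter), which means that a large rise here is not confined to branching, and the unbranched chain of compound 4 goes against any such reading. Nothing measured on these compounds accounts for the rise, so its origin stays unexplained.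

This single change alters several things at once: the ring gives way to an open chain, a nitrogen turns the amide into a urea, and a chlorine ends the chain, so the compounds shown cannot tell which of these carries the rise. A plain hexyl chain without the chlorine, or a urea carrying cyclopentylmethyl on its nitrogen, would be the groups that pull these parts apart.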